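A few compounds are considered here, and "the series" means these few. Any claim that something is new, unique, unknown or untested is made for them only; others in the source may bear on it.

Three compounds share one core and differ only in the sulfonyl-bearing heteroaryl group. Compound 1 `O=S(=O)(c1ccc2cccnc2c1)n1cc(C2=CCNCC2)c2ccccc21` gives 7 nM in an assay on HEK293 cells for displacement of a labelled ligand from 5-hydroxytryptamine receptor 6 (Homo sapiens), read by scintillation counting; a lower number here means a stronger inhibitor, a higher number a weaker inhibitor; compound 2 `O=S(=O)(c1cc2ccccc2cn1)n1cc(C2=CCNCC2)c2ccccc21` gives 12 nM and compound 3 `O=S(=O)(c1cncc2ccccc12)n1cc(C2=CCNCC2)c2ccccc21` gives 5 nM in this assay. The number for compound 1 lies among the other two, and all three fall within the usual scatter of one another, so none can be set apart.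

Compound 4 `O=S(=O)(c1ccc2cccnc2c1)n1cc(C2=CCNCC2)c2cc(Cl)ccc21` keeps the sulfonyl group of compound 1 and differs by chloro in place of hydrogen on an aromatic carbon. Going by the values given here, no measured pair shows this change, so the expected step from compound 1 to compound 4 in this assay is a 1.4-fold lower number from compound 1 to compound 4 (0.15 log units; within the scatter), that is, nothing beyond the scatter or a modest gain. Compound 4 is therefore estimated at 5 nM in this assay, within 1.5 nM to 15 nM.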

Compound 4, inhibition constant: 9 nM
For compound 4 the middle estimate is 1.8-fold (0.26 log units) below the measured one; low and high end bracket the measured number.
By their numbers in this assay, from the lowest: compounds 3, 1, 4 and 2 (each within the scatter of the next, the first and the last beyond it).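

Compound 4 carries its change on the shared core, whereas compounds 1 to 3 differ only in the sulfonyl-bearing group. In this assay chloro in place of hydrogen on this aromatic carbon gives a 1.3-fold higher number from compound 1 to compound 4 (0.11 log units; within the scatter), so this position accepts chloro with no shift that stands out from the scatter. Nothing at hand accounts for this result. On these data alone, it remains open whether other groups at this carbon, such as methoxy, an amine or a carboxylic acid, would move the number. Also open, as far as these compounds go, is whether chloro elsewhere on the core would behave in the same way.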